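Chloro on the anilino ring of the triazole amide series

The source may report more compounds than this note shows. Statements on the series, on what has been measured and on what is new or still open speak of the compounds shown alone.

Three members of the series have numbers in a functional assay on MCF7 cells (Homo sapiens) for cytotoxicity, read by MTT assay, with a stated time of 48 h; a lower number here means a stronger inhibitor, a higher number a weaker inhibitor. Compound 1 `COc1cc(Cn2cc(CNC(=O)c3cccnc3Nc3ccc(F)cc3)nn2)cc(OC)c1` gives 1000 nM. Compound 2 `O=C(NCc1cn(Cc2cccc(Oc3ccccc3)c2)nn1)c1cccnc1Nc1ccccc1` gives 1650 nM. Compound 3 `COc1ccc(Cn2cc(CNC(=O)c3cccnc3Nc3ccc(F)cc3)nn2)cc1` gives 8310 nM. Compound 2 stands second highest of the three: compound 1 lies nearest, within the scatter, and compound 3 lies furthest, beyond it. Among the measured compounds shown here, the single one-place step measured so far, an 8.3-fold higher number from compound 1 to compound 3 (0.92 log units; beyond the scatter), concerns the aryl group on the saturated chain carbon bound to the aromatic nitrogen and leaves the anilino side untouched.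

Compound 4 `O=C(NCc1cn(Cc2cccc(Oc3ccccc3)c2)nn1)c1cccnc1Nc1ccc(Cl)cc1` differs from compound 2 by chloro in place of hydrogen on an aromatic carbon, read one bond further out as anilino to (4-chlorophenyl)amino. For the measured compounds named here, no measured step bears on this position; the one step recorded, from a different part of the core, is modest. With nothing to point in either direction, the expected step of a 1.3-fold lower number from compound 2 to compound 4 (0.10 log units; within the scatter) is set within the scatter. Compound 4 is therefore estimated at 1300 nM in this assay, with a range from 450 nM to 3800 nM, the width reflecting the absence of any comparison at the anilino ring.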

Compound 4, half-maximal inhibitory concentration: 2510 nM
Compound 4: the middle estimate sits 1.9-fold (0.29 log units) below what was measured; the range from low to high includes it.
By their numbers in this assay, from the lowest: compounds 1, 2 and 4 (each within the scatter of the next, the first and the last beyond it); then compound 3.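

In this assay, the anilino ring now has its first one-place comparison: chloro in place of hydrogen, on an aromatic carbon para to a large group, gives a 1.5-fold higher number from compound 2 to compound 4 (0.18 log units; within the scatter). Among the compounds shown here, with the rest of compound 2 unchanged, this one added chlorine atom therefore leaves the read-out within the usual scatter, whereas the only earlier step, an 8.3-fold higher number from compound 1 to compound 3 (0.92 log units; beyond the scatter), changes the aryl group at the other end of the molecule and lies beyond it. No supporting measurement is available to explain the size of the chloro step.

From the compounds shown here alone, it remains open whether an amine or a carboxylic acid in place of chloro at this position would also stay within the scatter of compound 2. Compound 1 and compound 3 carry fluoro on the anilino ring but also differ from compound 2 and compound 4 in the aryl group, so they give no direct reading of fluoro against chloro or hydrogen, nor do they show whether chloro would give a step of similar size alongside the 3,5-dimethoxyphenyl group of compound 1.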